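This account rests on a few compounds, and the source may have more. Where it says the series, first, only, none or still open, it means among the compounds named here.

Measured so far in a functional assay on HeLa cells (Homo sapiens) for cytotoxicity, read by MTT assay, with a stated time of 48 h; a higher number here means a weaker inhibitor, a lower number a stronger inhibitor:

Compound 1 `C#CC1=CC[C@]2(CC1)C(=C)CC[C@H]2C(C)C` gives 97600 nM 
Compound 2 `C=C1CCC[C@]2(C)CCC(c3cn(-c4cccc([N+](=O)[O-])c4)nn3)=CC[C@@]12C` gives 31900 nM 

Of these two, compound 2 has the lower number and is therefore the stronger inhibitor. The gap up to compound 1 lies beyond the usual scatter.

Compound 3 `C=C1CCC[C@]2(C)CCC(c3cn(-c4ccc(C)cc4)nn3)=CC[C@@]12C` has not yet been measured and keeps the core of compound 2. It carries 4-methylphenyl in place of 3-nitrophenyl on an aromatic nitrogen and differs from compound 2 in that one place. Within the data shown here, no two measured compounds differ in one place only, so the data give no direct guide to the size of such a step in this assay. The starting point is therefore compound 2 at 31900 nM and no step beyond the scatter is expected, with a slight lean toward a higher number. The expected change is a 1.2-fold higher number from compound 2 to compound 3 (0.08 log units; within the scatter) for this exchange of groups. For compound 3 the estimated value is 38000 nM with an expected range from 15000 nM to 95000 nM in this measurement.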

Compound 3, half-maximal inhibitory concentration: 69100 nM
The estimate for compound 3 lay 1.8-fold (0.26 log units) below the measured number; the range from low to high includes it.
By their numbers in this assay, from the lowest: compound 2; then compounds 3 and 1 (each within the scatter of the next).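

Among these compounds, the exchange of 3-nitrophenyl for 4-methylphenyl on the aromatic nitrogen of the five-membered ring gives the first direct reading of this position in this assay, with a 2.2-fold higher number from compound 2 to compound 3 (0.34 log units; beyond the scatter). The step is modest, but it shows that the group on this nitrogen is not silent in this read-out, and in this one pair the lower number belongs to the compound with 3-nitrophenyl. No accompanying measurement bears on the reason for the step, and since nitro gives way to methyl while the number in the group's name changes from 3 to 4, this single exchange cannot separate those two changes.

Still open, as far as these compounds go, is how the pair 3-methylphenyl and 4-nitrophenyl, or an unsubstituted phenyl, would read at this nitrogen, which would show whether the identity of the substituent or its place on the phenyl ring carries the step. Also open, from the compounds shown here alone, is what an aminophenyl group, a carboxylic acid on the phenyl ring or a plain alkyl chain would do here, and whether the step would carry over to another core.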